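Aryl replacement of trifluoromethoxy on the benzyl ring

A few compounds are considered here, and "the series" means these few. Any claim that something is new, unique, unknown or untested is made for them only; others in the source may bear on it.

Measured so far in a functional assay on CHO cells for antagonist activity at Orexin receptor type 2 (Homo sapiens), read by FLIPR and calcium flux; on this read-out higher numbers stand for weaker inhibition and lower numbers for stronger inhibition:
compound 1 `COc1cccc(OC)c1C1CCCC(=O)N1Cc1ccccc1` gives 416 nM
compound 2 `COc1cccc(OC)c1C1CCCC(=O)N1Cc1cccc(OC(F)(F)F)c1` gives 94 nM
compound 3 `COc1cccc(OC)c1C1CCCC(=O)N1Cc1cccc(-c2ccccc2)n1` gives 43 nM

Compound 2 stands second highest of the three numbers in this assay; compound 3 lies nearest, and compound 1 furthest, with both gaps beyond the scatter. The one single-point step shown is a 4.4-fold lower number from compound 1 to compound 2 (0.65 log units; beyond the scatter), a modest gain on adding trifluoromethoxy to the unsubstituted benzyl group.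

Compound 4 `COc1cccc(OC)c1C1CCCC(=O)N1Cc1cccc(-c2ccccn2)c1` is not yet measured. It differs from compound 2 in one place: pyridin-2-yl in place of trifluoromethoxy on an aromatic carbon, the new group sitting on an aromatic carbon of a six-membered aromatic ring of carbon only, meta to a large group. Among the compounds with values here, no measured pair reports this exact exchange. Compound 3 carries an aryl group on a different ring and is not a single-point comparator to compound 2, so its value only shows that an aryl substituent on the benzylic ring is compatible with the lower numbers seen in the series. The direction of change in this assay is therefore uncertain; a step within or near the scatter, slightly toward a lower number, is expected.

For compound 4 the estimate is 60 nM (range 20 nM to 180 nM), a step of a 1.6-fold lower number from compound 2 to compound 4 (0.19 log units; within the scatter) expected.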

Compound 4, half-maximal inhibitory concentration: 8 nM
Beside the measured number, compound 4's estimate is 7.5-fold (0.88 log units) above it; the measured number lies below the stated range.
By their numbers in this assay, from the lowest: compound 4; then compound 3; then compound 2; then compound 1.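

In this assay the exchange of trifluoromethoxy for pyridin-2-yl on this aromatic carbon gives a 12-fold lower number from compound 2 to compound 4 (1.07 log units; beyond the scatter), which shows that this position accepts a six-membered aromatic ring and that the gain available here goes well past what trifluoromethoxy delivered. Set against the unsubstituted benzyl group, the same change gives a 52-fold lower number from compound 1 to compound 4 (1.72 log units; beyond the scatter), a much larger step than the earlier 4.4-fold lower number from compound 1 to compound 2 (0.65 log units; beyond the scatter), so the choice of group at this carbon, and not merely the presence of a substituent, strongly affects the number in this series. No supporting evidence is available on why the step is this large.

Going by these compounds, whether the ring nitrogen contributes to the gain remains open: phenyl on this same carbon would separate the effect of the aromatic ring from that of the nitrogen, while pyridin-3-yl and pyridin-4-yl would test where the nitrogen sits. Also open, on these data alone, is how far this position extends to other kinds of group, such as a morpholine, a carboxylic acid or a longer alkyl chain.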